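Two Methoxy Groups Added Where One Made No Difference

A few compounds are considered here, and "the series" means these few. Any claim that something is new, unique, unknown or untested is made for them only; others in the source may bear on it.

Three compounds built on one shared core were examined in an ADME assay on HEK293 cells (Homo sapiens) for cytotoxicity, read by MTT assay, with a stated time of 48 h; on this read-out higher numbers stand for weaker inhibition and lower numbers for stronger inhibition. Compound 1 `COc1ccc(-c2nc(SCC(=O)c3sc(-c4ccccc4)nc3C)[nH]c(=O)c2C#N)cc1` gives 76200 nM. Compound 3 `Cc1nc(-c2ccccc2)sc1C(=O)CSc1nc(-c2ccccc2)c(C#N)c(=O)[nH]1` gives 93500 nM, which is the higher of the two numbers available, although the gap to compound 1 is within the scatter, so the two cannot be ranked. Among the compounds with values here, the only single-point step among the measured compounds, a 1.2-fold higher number from compound 1 to compound 3 (0.09 log units; within the scatter), put hydrogen in place of methoxy on an aromatic carbon and left the read-out essentially unchanged. Compound 2 `COc1ccc(-c2nc(C)c(C(=O)CSc3nc(N)c(C#N)c(-c4ccc(OC)cc4)n3)s2)cc1` gives "not determined" (no result reported) in this assay, so no result was reported for it.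

Compound 4 `COc1ccc(-c2nc(SCC(=O)c3sc(-c4ccccc4)nc3C)[nH]c(=O)c2C#N)cc1OC` differs from compound 3 by 3,4-dimethoxyphenyl in place of phenyl on an aromatic carbon. Within the data shown here, the one measured step that bears on this change is the methoxy-for-hydrogen swap between compound 1 and compound 3, and it produced a shift within the scatter. Adding methoxy groups at this position is therefore expected to give a step no larger than the scatter, and the expected step of a 1.1-fold lower number from compound 3 to compound 4 (0.04 log units; within the scatter) reflects that. On this basis compound 4 is estimated to give 85000 nM in this assay, with an expected range from 38000 nM to 190000 nM.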

Compound 4, half-maximal inhibitory concentration: 91800 nM
Compound 4: the middle estimate sits 1.1-fold (0.03 log units) below what was measured; measured number inside the range.
By their numbers in this assay, from the lowest: compounds 1, 4 and 3 (each within the scatter of the next).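

Compound 3 and compound 4 differ only in phenyl against 3,4-dimethoxyphenyl, and this assay gives a step of a 1.0-fold lower number from compound 3 to compound 4 (0.01 log units; within the scatter) for this larger swap, which brings in 10 heavy atoms where 6 stood and 2 hydrogen-bond acceptors where there were 0. Within the data shown here, the earlier compounds covered only one methoxy group, whereas the step of a 1.2-fold higher number from compound 1 to compound 4 (0.08 log units; within the scatter) now adds a second, so on this position of the shared core neither one methoxy group nor two separates these compounds, and compounds 1, 3 and 4 cannot be put in order. Nothing available explains why these numbers stay so close together.

From the compounds shown here alone, every group compared at this position is a phenyl ring carrying only hydrogen or methoxy, so it remains open whether an amine or a carboxylic acid on that ring, or a longer chain in place of methoxy, would move the number beyond the scatter. Going by these compounds, it is also open whether replacing the phenyl ring with a small group such as methyl would do so.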